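Notes on compound 4: methyl position on the phenoxy group

The source may hold more compounds than are shown below. What is called first, only, known or untested is meant among the compounds shown, and "the series" means these compounds.

Measured so far:
- compound 1 `Cc1nn(C)c(Oc2ccc(Cl)cc2)c1/C=N\CCCCCCOc1cc2oc(=O)cc(C)c2cc1Cl`: in a functional assay on HepG2 cells (Homo sapiens) for antiproliferative activity, read by MTT assay, with a stated time of 72 h (on this read-out higher numbers stand for weaker inhibition and lower numbers for stronger inhibition), compound 1 gives 2960 nM
- compound 2 `Cc1nn(C)c(Oc2cccc(Br)c2)c1/C=N\CCCCCCOc1cc2oc(=O)cc(C)c2cc1Cl`: in this assay compound 2 gives 6830 nM
- compound 3 `Cc1ccccc1Oc1c(/C=N\CCCCCCOc2cc3oc(=O)cc(C)c3cc2Cl)c(C)nn1C`: in this assay compound 3 gives 7830 nM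

Compound 3 stands at the highest number of the three. Against compound 2 the gap is within the scatter, so the two cannot be ordered; against compound 1 the step is a 2.6-fold higher number from compound 1 to compound 3 (0.42 log units; beyond the scatter), beyond the scatter. The other step into compound 3, a 1.1-fold higher number from compound 2 to compound 3 (0.06 log units; within the scatter), is within the scatter.

Compound 4 `Cc1ccc(Oc2c(/C=N\CCCCCCOc3cc4oc(=O)cc(C)c4cc3Cl)c(C)nn2C)cc1` differs from compound 3 by 4-methylphenyl in place of 2-methylphenyl on an oxygen on an aromatic ring. Among the compounds with values here, no measured step moves a methyl group around the same phenyl ring, so the change is only loosely covered. What the set does show is that the one 4-substituted phenyl, compound 1, carries the lowest number, with a 2.3-fold higher number from compound 1 to compound 2 (0.36 log units; beyond the scatter) and a 2.6-fold higher number from compound 1 to compound 3 (0.42 log units; beyond the scatter) both beyond the scatter on leaving that pattern. On that slim basis a modest step to a lower number in this assay is expected, a 1.7-fold lower number from compound 3 to compound 4 (0.24 log units; within the scatter), though a result within the scatter of compound 3 would not surprise. The estimate for compound 4 is 4500 nM, with a range of 2000 nM to 10000 nM.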

Compound 4, half-maximal inhibitory concentration: 20700 nM
Estimate against measurement, compound 4: 4.6-fold (0.66 log units) below; measured number outside the range, above it.
By their numbers in this assay, from the lowest: compound 1; then compounds 2 and 3 (each within the scatter of the next); then compound 4.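

In this assay, the 2-methylphenyl and 4-methylphenyl compounds have the same atoms joined differently, yet they do not read alike (a 2.6-fold higher number from compound 3 to compound 4 (0.42 log units; beyond the scatter)), so the place of the methyl on the phenoxy ring matters on its own. The 4-position pattern suggested by compound 1 does not hold as a general rule: compound 4 also carries a 4-substituted phenyl, but the exchange of chloro for methyl on an aromatic carbon separates the two (a 7.0-fold higher number from compound 1 to compound 4 (0.84 log units; beyond the scatter)), so the group at that place counts as well as the place itself. Compound 4 also stands apart from the 3-bromophenyl compound (a 3.0-fold higher number from compound 2 to compound 4 (0.48 log units; beyond the scatter)), and with all its steps beyond the scatter it carries the highest number of the four.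

Open, as far as these compounds go, is whether 4-fluorophenyl or 4-methoxyphenyl would read nearer compound 1 or compound 4, and whether 2-chlorophenyl would differ from compound 1 as 2-methylphenyl differs from compound 4. Nothing measured on these compounds bears on what lies behind these steps.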